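A few compounds are considered here, and "the series" means these few. Any claim that something is new, unique, unknown or untested is made for them only; others in the source may bear on it.

Working notes on the series. Compound 3 `CCNc1nc(N)c2nc(O)n(Cc3ccccc3)c2n1` carries an ethylamino group on the shared core; in a functional assay (spleen, spleen) for activation, with Mus musculus as the target (a higher number here means that more compound is needed for the effect, a lower number that less compound is needed), compound 3 gives 1 uM, the lowest of the three numbers measured. The two comparators lack that group: compound 1 `COc1ccc(Cn2c(O)nc3c(N)ncnc32)cc1` gives 10 uM and compound 2 `Nc1ncnc2c1nc(O)n2Cc1ccc(Cl)cc1` gives 10 uM, each a higher number than compound 3, beyond the scatter. Within the data shown here, the one counted step among measured compounds, no change at the digits printed from compound 1 to compound 2 (within the scatter), lies within the scatter.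

Compound 4 `CCCCCNc1nc(N)c2nc(O)n(Cc3ccccc3)c2n1` is next in line. Relative to compound 3 the difference is propyl in place of hydrogen on a saturated chain carbon, two bonds along the chain from a nitrogen on an aromatic ring. Among the measured compounds shown here, no measured step bears on this change: the step from compound 1 to compound 2 concerns an aromatic substituent, not the chain on the ring nitrogen, and no other pair differs in the chain length. The expectation is therefore that compound 4 stays close to compound 3, with a step of no change at the digits printed from compound 3 to compound 4 (within the scatter) not beyond the scatter in either direction. Compound 4 is estimated at 1 uM, within 0.3 uM to 3 uM.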

Compound 4, minimum effective concentration: 0.1 uM
For compound 4 the middle estimate is 10-fold (1.00 log units) above the measured one; the measured number lies below the stated range.
By their numbers in this assay, from the lowest: compound 4; then compound 3; then compounds 1 and 2 (each within the scatter of the next).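

In this assay, among these compounds, the change from ethylamino to pentylamino gives a 10-fold lower number from compound 3 to compound 4 (1.00 log units; beyond the scatter) on the shared core, the first counted step that goes beyond the scatter and the first that bears on this chain. The saturated chain carbon two bonds along the chain from a nitrogen on an aromatic ring is thus a place where adding propyl lowers the amount of compound needed for the effect. No measured information here explains the size of this step.

Two chain lengths cannot show whether the number keeps falling with a longer chain such as octyl, or how a branched chain, a terminal amine or a carboxylic acid would read at this place. On these data alone, whether pentylamino acts alike with the methoxy or chloro substituent of compound 1 and compound 2 also remains open.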